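The source may report more compounds than this note shows. Statements on the series, on what has been measured and on what is new or still open speak of the compounds shown alone.

Of the compounds shown here, two have numbers so far in a functional assay on A2780 cells (Homo sapiens) for cytotoxicity; on this read-out higher numbers stand for weaker inhibition and lower numbers for stronger inhibition. Compound 1 (`CC(=O)Oc1cc(O)cc(CCCCCCC/C=C\CCCCCCCc2cc(O)cc(OC(C)=O)c2)c1`) gives 9.4 ug/mL, and compound 2 (`Oc1cc(O)cc(CCCCC/C=C\CCCCCCCc2cc(O)cc(O)c2)c1`) gives 9.8 ug/mL. These two values lie within the scatter of each other, which places compound 2 level with compound 1.

Compound 3 (`COc1cc(O)cc(CCCCCCC/C=C\CCCCCCCc2cc(O)cc(O)c2)c1`) has not yet been measured in this assay. Its difference from compound 2 is 2-(3-hydroxy-5-methoxyphenyl)ethyl in place of 3,5-dihydroxyphenyl on a saturated chain carbon, five bonds along the chain from a double-bonded chain carbon.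

Going by the values given here, the series offers no measured step that could be carried over to this change, and the data give no direction for it. Among the compounds with values here, the only guide is the level pair, compound 1 at 9.4 ug/mL and compound 2 at 9.8 ug/mL. No shift beyond the scatter is therefore expected in this assay. The estimated step of a 1.1-fold lower number from compound 2 to compound 3 (0.04 log units; within the scatter) stays within the scatter. Compound 3 is expected at 9 ug/mL, with an estimated range of 4 ug/mL to 20 ug/mL.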

Compound 3, half-maximal inhibitory concentration: 10 ug/mL
The estimate for compound 3 lay 1.1-fold (0.05 log units) below the measured number; low and high end bracket the measured number.
By their numbers in this assay, from the lowest: compounds 1, 2 and 3 (each within the scatter of the next).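

In this assay, replacing 3,5-dihydroxyphenyl with 2-(3-hydroxy-5-methoxyphenyl)ethyl on a saturated chain carbon, five bonds along the chain from a double-bonded chain carbon, gives a 1.0-fold higher number from compound 2 to compound 3 (0.01 log units; within the scatter). Going by these compounds alone, this is the first single-place step, and it shows that this read-out does not separate the two groups at this place, even though the entering group is larger and carries a methoxy group. No measurement bears on why the number stays level across this change.

The step changes the ring substitution and the chain length together, and the compounds shown hold no pair that separates the methoxy group from the added ethyl link, so a level result for the whole change cannot be assigned to either part. On these data alone, it also remains open whether a much longer chain at this place, or a ring carrying an amine or a carboxylic acid in place of the methoxy group, would move the number beyond the scatter in this assay.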